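The source may report more compounds than this note shows. Statements on the series, on what has been measured and on what is new or still open speak of the compounds shown alone.

Three compounds share one core and differ only in the aromatic group attached to a carbonyl carbon: compound 1 `COc1ccc(C(=O)c2ccc3c(c2)C(n2ccccc2=O)=CC(C)(C)O3)cc1`, compound 2 `CC1(C)C=C(n2ccccc2=O)c2cc(C(=O)c3ccco3)ccc2O1` and compound 3 `CC1(C)C=C(n2ccccc2=O)c2cc(C(=O)c3ccc([N+](=O)[O-])cc3)ccc2O1`. In a functional assay (aorta) with Rattus norvegicus as the target (on this read-out lower numbers stand for lower potency and higher numbers for higher potency (the scale is a negative logarithm)), compound 1 gives 6.15, compound 2 gives 6.49 and compound 3 gives 6.2, so compound 3 sits second highest of the three, within the scatter of both others. The two earlier swaps at that carbonyl carbon gave a number 0.34 log units higher from compound 1 to compound 2 (beyond the scatter) and a number 0.29 log units lower from compound 2 to compound 3 (within the scatter). Compound 4 `CC1(C)C=C(n2ccccc2=O)c2cc(C(=O)c3c(F)cccc3F)ccc2O1` carries a further swap of the same kind: 2,6-difluorophenyl in place of 4-nitrophenyl on a carbonyl carbon. With both earlier swaps so small, no step beyond the scatter is expected for compound 4, a number 0.10 log units higher from compound 3 to compound 4 (within the scatter). Compound 4 is therefore estimated at 6.3, with a range from 5.8 to 6.8.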

Compound 4, logarithm of the reciprocal of the active concentration, log(1/C): 6.97
Beside the measured number, compound 4's estimate is 0.67 log units below it, outside the stated range (above it).
By their numbers in this assay, from the lowest: compounds 1, 3 and 2 (each within the scatter of the next, the first and the last beyond it); then compound 4.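

At this carbonyl carbon, the choice of aromatic group can matter more than compounds 1 to 3 suggested: 2,6-difluorophenyl gives a clear gain over 4-nitrophenyl (a number 0.77 log units higher from compound 3 to compound 4 (beyond the scatter)), furan-2-yl (a number 0.48 log units higher from compound 2 to compound 4 (beyond the scatter)) and 4-methoxyphenyl (a number 0.82 log units higher from compound 1 to compound 4 (beyond the scatter)). Compound 4 is thus the only one that stands clear of all the others. Nothing available here explains this gain. From the compounds shown here alone, whether it requires both fluorines remains open. Comparisons with plain phenyl, 2-fluorophenyl and 2,6-dichlorophenyl would help separate the contribution of the fluorines from that of the ring.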